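Swapping an aromatic for a saturated ring on the shared core

A few compounds are considered here, and "the series" means these few. Any claim that something is new, unique, unknown or untested is made for them only; others in the source may bear on it.

Measured compounds:
compound 1 `CCC(C)(C)Cc1c[nH]c(CCc2ccc(-c3cccc(C)n3)cc2)n1`: 102 nM
compound 2 `CCC(C)(C)Cc1c[nH]c(CCc2ccc(-c3cccc(N)n3)cc2)n1`: 97 nM
compound 3 `CCC(C)(C)Cc1c[nH]c(CCc2ccc(-c3cnsc3)cc2)n1`: 100 nM

Of the compounds shown here, three have been measured in a functional assay on HEK293 cells for agonist activity at Bombesin receptor subtype-3 (Homo sapiens), read by luminescence and calcium flux, with a stated time of 10 min; a higher number here means that more compound is needed for the effect, a lower number that less compound is needed. Compound 1 gives the highest number of the three, yet its steps to both neighbours stay within the scatter: a 1.1-fold lower number from compound 1 to compound 2 (0.02 log units; within the scatter) and a 1.0-fold lower number from compound 1 to compound 3 (0.01 log units; within the scatter). The step of a 1.0-fold higher number from compound 2 to compound 3 (0.01 log units; within the scatter) is equally small, so the three values show no ordering at all.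

Compound 4 `CCC(C)(C)Cc1c[nH]c(CCc2ccc(N3CCCCC3)cc2)n1` is not yet measured. It differs from compound 1 as follows: piperidin-1-yl in place of 6-methylpyridin-2-yl on an aromatic carbon. The three measured steps all bear on this position, each exchanging one aromatic group for another, and all left the readout unchanged. None, however, brings in a non-aromatic ring, so they speak only indirectly for compound 4. Given the flat picture across compounds 1, 2 and 3, compound 4 is expected to show a step of a 1.5-fold higher number from compound 1 to compound 4 (0.17 log units; within the scatter) in this assay, that is, little change, with a wider range to allow for the untested ring type. The estimate for compound 4 is 150 nM, between 50 nM and 600 nM.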

Compound 4, half-maximal effective concentration: 108 nM
Compound 4: middle estimate off by 1.4-fold (0.14 log units), on the high side; measured number inside the range.
By their numbers in this assay, from the lowest: compounds 2, 3, 1 and 4 (each within the scatter of the next).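

Within the data shown here, compound 4 puts a non-aromatic ring on this aromatic carbon for the first time, and in this assay the readout stays flat whichever aromatic neighbour it is set against, with a 1.1-fold higher number from compound 1 to compound 4 (0.02 log units; within the scatter) and a 1.1-fold higher number from compound 3 to compound 4 (0.03 log units; within the scatter) and also a 1.1-fold higher number from compound 2 to compound 4 (0.05 log units; within the scatter). Among these four compounds, then, the position accepts piperidin-1-yl as well as the 6-methylpyridin-2-yl, 6-aminopyridin-2-yl and 1,2-thiazol-4-yl groups, so an aromatic ring at this place is not required to keep the number where it stands. No supporting data are available to explain why these exchanges leave the readout unchanged.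

The compounds shown leave open whether a ring-free group here, such as dimethylamino or a carboxylic acid, would hold the readout as well. They also leave open whether morpholine would match piperidin-1-yl.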